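The compounds below may be only part of what the source reports. "The series", "measured", "known", "first", "only" and "open" are said of these compounds alone.

Compound 1 `COc1ccc2nc(C)cc(OCC(=O)Nc3cccc(C)c3)c2c1` gives 4.83 in a physicochemical assay for lipophilicity, read by HPLC, in phosphate buffer, measured as chromatographic lipophilicity, at pH 7.4; on this read-out lower numbers stand for lower lipophilicity and higher numbers for higher lipophilicity.
Compound 2 `COc1cccc(NC(=O)COc2cc(C)nc3ccc(OC)cc23)c1` gives 4.49 in this assay.

Among the measured compounds shown here, compound 2 stands lowest of the two measured numbers; the only step so far, a number 0.34 log units lower from compound 1 to compound 2 (beyond the scatter), exchanges a methyl for a methoxy on the aromatic carbon. Compound 3 `COc1ccc(NC(=O)COc2cc(C)nc3ccc(OC)cc23)cc1` is not yet measured. It differs from compound 2 by 4-methoxyphenyl in place of 3-methoxyphenyl on an amide-type nitrogen, the same atoms joined differently. For the measured compounds named here, no measured step moves a group from one position to another, so the step from compound 1 to compound 2 does not bear directly on it. Compound 3 is therefore expected near compound 2, with a step of a number 0.04 log units lower from compound 2 to compound 3 (within the scatter) that need not exceed the scatter. The estimate for compound 3 is 4.45, between 4.15 and 4.75.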

Compound 3, distribution coefficient: 4.22
The estimate for compound 3 lay 0.23 log units above the measured number, within the range that was stated.
By their numbers in this assay, from the lowest: compounds 3 and 2 (each within the scatter of the next); then compound 1.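

With 4-methoxyphenyl in place of 3-methoxyphenyl on the amide-type nitrogen, this assay shows a number 0.27 log units lower from compound 2 to compound 3 (within the scatter), so the two placements of the methoxy are not told apart here. With 4-methoxyphenyl in place of 3-methylphenyl at the same nitrogen, the result is a number 0.61 log units lower from compound 1 to compound 3 (beyond the scatter), a change that does exceed the scatter. No supporting measurement accounts for either step.

The compounds shown leave open how a phenyl carrying an amine or a carboxylic acid would read in this assay. They also leave open whether a longer chain in place of the methoxy would do the same.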